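The compounds below may be only part of what the source reports. "The series", "measured", "known", "first", "only" and "open" are said of these compounds alone.

In a functional assay on a cell-free system (plasma, Oryctolagus cuniculus) for inhibition, with stated times of 5 min, 1 min and 6 min (on this read-out higher numbers stand for weaker inhibition and lower numbers for stronger inhibition), compound 1 `CCOC(=O)c1c(C)nc(-c2cccc(C#N)c2)n1OC` gives 9130 nM, the highest of the three numbers in hand, although all three lie within the scatter of one another. Compound 2 `CCOC(=O)c1c(C)nc(-c2cccc(C#N)c2)n1OC(C)C` gives 6740 nM, and compound 3 `CCOC(=O)c1c(C)nc(-c2cccc(C#N)c2)n1OCc1ccccc1Cl` gives 8710 nM. The step of a 1.4-fold lower number from compound 1 to compound 2 (0.13 log units; within the scatter) and the step of a 1.0-fold lower number from compound 1 to compound 3 (0.02 log units; within the scatter) both stay within the scatter, as does the step of a 1.3-fold higher number from compound 2 to compound 3 (0.11 log units; within the scatter).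

Compound 4 `CCOC(=O)c1c(C)nc(-c2cccc(C#N)c2)n1OCc1ccc(C)cc1` differs from compound 1 by 4-methylphenyl in place of hydrogen on a saturated chain carbon bound to an oxygen on an aromatic ring. The measured step that bears most directly on this change is a 1.0-fold lower number from compound 1 to compound 3 (0.02 log units; within the scatter), where a 2-chlorophenyl entered the same place on the saturated chain carbon bound to an oxygen on an aromatic ring and the number did not move beyond the scatter. The step of a 1.4-fold lower number from compound 1 to compound 2 (0.13 log units; within the scatter) shows the same flat response to a change on that oxygen. Nothing among these three compounds gives a reason to expect the number for compound 4 to move beyond the scatter in either direction, so the step of a 1.1-fold lower number from compound 1 to compound 4 (0.03 log units; within the scatter) is expected to be small. Compound 4 is therefore estimated at 8500 nM in this assay, with a range from 4500 nM to 16000 nM.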

Compound 4, half-maximal inhibitory concentration: 6310 nM
Compound 4: the middle estimate sits 1.3-fold (0.13 log units) above what was measured; the range from low to high includes it.
By their numbers in this assay, from the lowest: compounds 4, 2, 3 and 1 (each within the scatter of the next).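

In this assay, a 4-methylphenyl on the saturated chain carbon bound to an oxygen on an aromatic ring gives a second case alongside the 2-chlorophenyl of compound 3: the step from hydrogen reads a 1.4-fold lower number from compound 1 to compound 4 (0.16 log units; within the scatter), and exchanging one ring for the other reads a 1.4-fold lower number from compound 3 to compound 4 (0.14 log units; within the scatter), so the two substituted rings cannot be told apart here. Against the isopropyl of compound 2, the 4-methylbenzyl gives a 1.1-fold lower number from compound 2 to compound 4 (0.03 log units; within the scatter), which means that methyl, isopropyl, 2-chlorobenzyl and 4-methylbenzyl on this oxygen are all connected by steps within the scatter, and no dependence on the group at this place can be read from them. Nothing at hand offers an explanation for this flat response.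

Going by these compounds, it remains open whether any group at this place can move the number beyond the scatter, such as a benzyl carrying a carboxylic acid or an amine, or a longer chain on the oxygen. Also open, on these data alone, is whether the same flat response would hold if the nitrile or the ethyl ester of the shared core were replaced.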